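Triazine series: propylamino to diethylamino, expected effect

This account rests on a few compounds, and the source may have more. Where it says the series, first, only, none or still open, it means among the compounds named here.

Measured compounds:
compound 1, `CNc1nc(Cl)nc(N[C@@H](C)c2ccccc2)n1`, 26900 nM
compound 2, `C[C@H](Nc1nc(Cl)nc(NC(C)(C)C)n1)c1ccccc1`, 7410 nM
compound 3, `CCCNc1nc(Cl)nc(N[C@@H](C)c2ccccc2)n1`, 15100 nM

In an ADME assay on the whole organism for inhibition, with Echinochloa crus-galli var. formosensis as the target, with a stated time of 4 days (a lower number here means a stronger inhibitor, a higher number a weaker inhibitor), compound 3 gives 15100 nM, the second highest of the three numbers. Toward compound 1 the gap is a 1.8-fold lower number from compound 1 to compound 3 (0.25 log units; within the scatter) reversed, within the scatter; toward compound 2 it is a 2.0-fold higher number from compound 2 to compound 3 (0.31 log units; beyond the scatter), beyond the scatter.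

Compound 4, `CCN(CC)c1nc(Cl)nc(N[C@@H](C)c2ccccc2)n1`, is not yet measured. The change from compound 3 is diethylamino in place of propylamino on an aromatic carbon.

For the measured compounds named here, three measured steps touch the same aromatic nitrogen. a 3.6-fold lower number from compound 1 to compound 2 (0.56 log units; beyond the scatter) is the largest, and a 2.0-fold higher number from compound 2 to compound 3 (0.31 log units; beyond the scatter) runs back part of the way; a 1.8-fold lower number from compound 1 to compound 3 (0.25 log units; within the scatter) is within the scatter. Branching at that nitrogen went with lower numbers, but no measured step removes the hydrogen-bond donor, so the present change has no direct precedent. Given that larger substitution here has so far moved numbers down only modestly, a modest step is expected in this assay, of uncertain direction and possibly within the scatter.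

For compound 4 the expected value is 12000 nM, range 4000 nM to 40000 nM. The expected step from compound 3 is a 1.3-fold lower number from compound 3 to compound 4 (0.10 log units; within the scatter).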

Compound 4, half-maximal inhibitory concentration: 257 nM
Compound 4: the middle estimate sits 47-fold (1.67 log units) above what was measured; measured number below the stated range.
By their numbers in this assay, from the lowest: compound 4; then compound 2; then compounds 3 and 1 (each within the scatter of the next).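

In this assay, for the compounds shown here, the change to diethylamino on the aromatic carbon opposite the ring nitrogen gives a 59-fold lower number from compound 3 to compound 4 (1.77 log units; beyond the scatter), and the other two comparisons at this position give a 29-fold lower number from compound 2 to compound 4 (1.46 log units; beyond the scatter) and a 100-fold lower number from compound 1 to compound 4 (2.02 log units; beyond the scatter), so this position can move the number far more than the earlier steps among methylamino, propylamino and (tert-butyl)amino suggested. Compound 4 is also the only compound shown with 0 hydrogen-bond donors in this group, and it sits clearly lower than the three compounds that keep 1 hydrogen-bond donor here, whether their chain is small, straight or branched. No supporting data bear on what lies behind this drop.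

With a single compound of this kind, the missing hydrogen-bond donor cannot be separated from the two ethyl groups themselves, and dimethylamino, dipropylamino or pyrrolidinyl in this place would be needed to tell how far the effect depends on the size and shape of the substituents. On these data alone, the chloro group and the group of 9 heavy atoms stay the same throughout, so whether the step holds with methoxy in place of chloro remains open.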